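The source may report more compounds than this note shows. Statements on the series, on what has been measured and on what is new or still open speak of the compounds shown alone.

Compound 1 `CN(C)c1nonc1/C(=N/O)Nc1ccc(F)c(Br)c1`: > 36.6 mL/min/kg (a limit)
Compound 2 `O/N=C(\Nc1ccc(F)c(Br)c1)c1nonc1NCc1ccccc1`: 35 mL/min/kg

Going by the values given here, in an ADME assay on liver (Rattus norvegicus) for metabolic stability, read by LC-MS, using S9 fraction, with a stated time of 30 min, tested at 5 uM, in the presence of a further agent that is not named here (on this read-out lower numbers stand for slow clearance and higher numbers for fast clearance), compound 2 gives 35 mL/min/kg, the only actual number so far. Compound 1 gives > 36.6 mL/min/kg, which is a limit of the assay and not a number.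

Compound 3 `CS(=O)(=O)NCCNc1nonc1/C(=N/O)Nc1ccc(F)c(Br)c1` keeps the core of compound 2 and changes only the amino side chain: (methanesulfonamido)methyl in place of phenyl on a saturated chain carbon bound to a nitrogen on an aromatic ring. In words, (methanesulfonamido)methyl stands in place of phenyl, so benzylamino becomes (2-(methanesulfonamido)ethyl)amino.

Among the compounds with values here, only one measured step bears on this, since it also alters that amino group: benzylamino in place of dimethylamino gave an at least 1.0-fold lower number from compound 1 to compound 2 (0.01 log units; that floor lies within the scatter). That is thin evidence, and it gives no ground to expect a large shift in this assay.

The estimated step is a 1.2-fold lower number from compound 2 to compound 3 (0.07 log units; within the scatter), expected to stay within the scatter. For compound 3, the expected clearance is 30 mL/min/kg, with an estimated range of 17 mL/min/kg to 37 mL/min/kg.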

Compound 3, clearance: 11.7 mL/min/kg
The estimate for compound 3 lay 2.6-fold (0.41 log units) above the measured number, outside the stated range (below it).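

Dimethylamino to benzylamino gave an at least 1.0-fold lower number from compound 1 to compound 2 (0.01 log units; that floor lies within the scatter), so that step did not show whether this amino side chain can move clearance at all in this assay. Compound 3 shows that it can: (methanesulfonamido)methyl in place of phenyl on a saturated chain carbon bound to a nitrogen on an aromatic ring gives a 3.0-fold lower number from compound 2 to compound 3 (0.48 log units; beyond the scatter). Measured against dimethylamino, (2-(methanesulfonamido)ethyl)amino gives an at least 3.1-fold lower number from compound 1 to compound 3 (0.49 log units; beyond the scatter), and this size is only a floor, since compound 1 carries a limit of the assay and not a number: the limit of > 36.6 mL/min/kg in this assay, at which 1 of the 3 values shown sits.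

The compounds shown cannot separate the loss of the phenyl ring from the arrival of the methanesulfonamido group, as both happen in the same change. A carboxylic acid, a hydroxyl group or a longer chain in this place would remain to be compared.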